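This account rests on a few compounds, and the source may have more. Where it says the series, first, only, none or still open, it means among the compounds named here.

Three measured analogues share one core. Compound 1 `COc1ccc2c(c1)OC(c1cc(OC)c(OC)c(OC)c1)C(C(=O)OC(C)C)=C2` gives 11800 nM in a functional assay for inhibition of nuclear factor NF-kappa-B complex (Homo sapiens); a higher number here means a weaker inhibitor, a lower number a stronger inhibitor. Compound 2 `COc1ccc2c(c1)OC(c1cc(OC)c(OC)c(OC)c1)C(C(=O)OCCc1ccccc1)=C2` gives 16200 nM in this assay, and compound 3 `CCOC(=O)C1=Cc2ccc(OC)cc2OC1c1cc(OC)c(OC)c(OC)c1` gives 25000 nM in this assay. Compound 2 thus holds the second highest of the three numbers, yet it sits within the scatter of both compound 1 and compound 3, so no order among the three can be claimed. The measured steps alter only the ester portion: a 1.4-fold higher number from compound 1 to compound 2 (0.14 log units; within the scatter), a 2.1-fold higher number from compound 1 to compound 3 (0.33 log units; beyond the scatter) and a 1.5-fold higher number from compound 2 to compound 3 (0.19 log units; within the scatter). Only the last of these reached beyond the scatter, and only modestly.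

Compound 4 `COc1ccc2c(c1)OC(c1cc(OC)c(OC)c(OC)c1)C(C#N)=C2` departs in another way: cyano in place of phenethyloxycarbonyl on a double-bonded ring carbon. Among the compounds with values here, no measured step removes the ester itself, so the earlier steps bear on this one only by showing that changes at this position shifted the number little. The step from compound 2 to compound 4 is therefore expected to be small, a 1.2-fold higher number from compound 2 to compound 4 (0.09 log units; within the scatter), and within the scatter. Compound 4 is expected to give about 20000 nM in this assay, with a range from 7000 nM to 60000 nM.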

Compound 4, half-maximal inhibitory concentration: 3400 nM
Compound 4: middle estimate off by 5.9-fold (0.77 log units), on the high side; the measured number lies below the stated range.
By their numbers in this assay, from the lowest: compound 4; then compounds 1, 2 and 3 (each within the scatter of the next, the first and the last beyond it).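

In this assay, the double-bonded ring carbon proves more responsive than the changes within the ester portion had suggested once the ester is replaced outright by cyano: a 4.8-fold lower number from compound 2 to compound 4 (0.68 log units; beyond the scatter), a 7.4-fold lower number from compound 3 to compound 4 (0.87 log units; beyond the scatter) and a 3.5-fold lower number from compound 1 to compound 4 (0.54 log units; beyond the scatter). All three steps lie beyond the scatter, so compound 4 stands apart from every ester shown, whichever ester group is taken as the starting point. Nothing available explains this shift.

On these data alone, how a carboxylic acid, a primary amide or a ketone on this same carbon would compare with cyano and with the esters remains open. Also open, as far as these compounds go, is whether cyano would still give a lower number than the esters on a core other than the one shared here.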